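Chain-length variation of the hydroxamic acid series

The source may report more compounds than this note shows. Statements on the series, on what has been measured and on what is new or still open speak of the compounds shown alone.

Measured compounds in a functional assay on HCT-116 cells (Homo sapiens) for inhibition, read by MTT assay, with a stated time of 72 h; a higher number here means a weaker inhibitor, a lower number a stronger inhibitor:
compound 1 `CNC(=O)CCCCCCCn1nc(-c2ccc3oc(N)nc3c2)c2c(N)ncnc21` gives 3150 nM
compound 2 `Nc1nc2cc(-c3nn(CC(=O)NO)c4ncnc(N)c34)ccc2o1` gives 11400 nM
compound 3 `Nc1nc2cc(-c3nn(CCCC(=O)NO)c4ncnc(N)c34)ccc2o1` gives 19600 nM

Compound 3 stands at the highest of the three numbers in this assay; its nearest neighbour is compound 2, separated by a 1.7-fold higher number from compound 2 to compound 3 (0.24 log units; within the scatter), and its furthest is compound 1, separated by a 6.2-fold higher number from compound 1 to compound 3 (0.79 log units; beyond the scatter).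

Compound 4 `Nc1nc2cc(-c3nn(CCCCC(=O)NO)c4ncnc(N)c34)ccc2o1` continues the same line of change. The difference from compound 3 is (hydroxycarbamoyl)methyl in place of hydroxycarbamoyl on a saturated chain carbon, three bonds along the chain from an aromatic nitrogen.

Going by the values given here, two measured steps bear on this. The step of a 1.7-fold higher number from compound 2 to compound 3 (0.24 log units; within the scatter) shows that lengthening the chain between the aromatic nitrogen and the hydroxycarbamoyl group left the number essentially unchanged. The step of a 6.2-fold higher number from compound 1 to compound 3 (0.79 log units; beyond the scatter) is beyond the scatter, but it exchanges the whole terminal group and so speaks less directly to a single added chain carbon. On that basis the expected step is a 1.1-fold higher number from compound 3 to compound 4 (0.03 log units; within the scatter), a change not beyond the scatter in either direction.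

Compound 4 is therefore estimated at 21000 nM in this assay, with a range from 8000 nM to 55000 nM.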

Compound 4, half-maximal inhibitory concentration: 34000 nM
Beside the measured number, compound 4's estimate is 1.6-fold (0.21 log units) below it; the measured number falls inside the stated range.
By their numbers in this assay, from the lowest: compound 1; then compounds 2, 3 and 4 (each within the scatter of the next, the first and the last beyond it).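

In this assay, the added chain carbon alone gives a 1.7-fold higher number from compound 3 to compound 4 (0.24 log units; within the scatter) and does not separate the two compounds. Taken together, the chain extensions from hydroxycarbamoyl to 3-(hydroxycarbamoyl)propyl give a 3.0-fold higher number from compound 2 to compound 4 (0.47 log units; beyond the scatter) and lie beyond the scatter even though neither of the two parts does, while an 11-fold higher number from compound 1 to compound 4 (1.03 log units; beyond the scatter) is the largest step in the set and sets the methylcarbamoyl compound further from the longest hydroxamic acid shown here than from the shorter ones. No measurement shown gives a reason for these steps.

Chain length and terminal group change together between compound 1 and the hydroxamic acids, so their separate contributions remain unresolved. A longer chain ending in hydroxycarbamoyl, or these same chains ending in a carboxylic acid, would bear on that question.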